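Methoxy on the pendant phenyl: a paired comparison

The source may report more compounds than this note shows. Statements on the series, on what has been measured and on what is new or still open speak of the compounds shown alone.

Compound 1 `Cc1ccc(C(=O)c2ccc(OCC(=O)Nc3nc(-c4ccccc4)cs3)c(C)c2)cc1` gives 29900 nM in a functional assay on Ehrlich cells (Mus musculus) for cytotoxicity, read by MTT assay, with a stated time of 48 h; on this read-out lower numbers stand for stronger inhibition and higher numbers for weaker inhibition. Compound 2 `COc1ccc(-c2csc(NC(=O)COc3ccc(C(=O)c4ccc(C)cc4)cc3C)n2)cc1` carries the change (methoxy in place of hydrogen on an aromatic carbon); in this assay compound 2 gives 20700 nM, a step of a 1.4-fold lower number from compound 1 to compound 2 (0.16 log units; within the scatter). Compound 3 `Cc1cc(C(=O)c2ccccc2)cc(C)c1OCC(=O)Nc1nc(-c2ccccc2)cs1` has the same atoms as compound 1 joined differently; the difference between the two cores is not broken down here. In this assay compound 3 gives 22700 nM, within the scatter of both compound 1 and compound 2. Compound 4 `COc1ccc(-c2csc(NC(=O)COc3c(C)cc(C(=O)c4ccccc4)cc3C)n2)cc1` is not yet measured; it differs from compound 3 by methoxy in place of hydrogen on an aromatic carbon, the same change as from compound 1 to compound 2, occurring twice among the compounds shown. The earlier step of a 1.4-fold lower number from compound 1 to compound 2 (0.16 log units; within the scatter) stayed within the scatter. For compound 4 a step of similar size is expected, a 1.2-fold lower number from compound 3 to compound 4 (0.09 log units; within the scatter). Compound 4 is therefore estimated near 18500 nM, between 10000 nM and 35000 nM.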

Compound 4, half-maximal inhibitory concentration: 41200 nM
Estimate against measurement, compound 4: 2.2-fold (0.35 log units) below; measured number outside the range, above it.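

In this assay, methoxy in place of hydrogen on the core of compound 3 gives a 1.8-fold higher number from compound 3 to compound 4 (0.26 log units; within the scatter). Set beside the earlier step, the two cores do not separate: the same change on two cores in this assay, a 1.4-fold lower number (0.16 log units; within the scatter) from compound 1 to compound 2 and a 1.8-fold higher number (0.26 log units; within the scatter) from compound 3 to compound 4, 2.6-fold (0.42 log units) apart, within the scatter of two such steps. Phenyl to 4-methoxyphenyl thus stays within the scatter on both cores, which gives no ground for saying that the change carries differently between them, but two pairs do not show that it would behave the same way on a further core.

The compounds shown leave open whether another group in the same place, such as an amine or a carboxylic acid, would give a step beyond the scatter. As far as these compounds go, whether a longer chain, such as ethoxy, would do so also remains open.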